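A few compounds are considered here, and "the series" means these few. Any claim that something is new, unique, unknown or untested is made for them only; others in the source may bear on it.

Two compounds of the series have numbers in an assay on LM cells with Alpha-1B adrenergic receptor (Homo sapiens) as the target; on this read-out higher numbers stand for weaker inhibition and lower numbers for stronger inhibition. Compound 1 `COCC1=C(C(=O)NCCCN2CCC(c3ccccc3C#N)CC2)[C@@H](c2ccc(F)c(F)c2)NC(=O)N1` gives 285 nM in this assay; compound 2 `N#Cc1cc(F)ccc1C1CCN(CCCNC(=O)C2=C(C(F)(F)F)NC(=O)N[C@@H]2c2ccc(F)c(F)c2)CC1` gives 200 nM in this assay, the lowest of the two, though its gap to compound 1 stays within the scatter. Compound 3 `COCC1=C(C(=O)NCCCN2CCC(c3ccc(F)cc3C#N)CC2)[C@@H](c2ccc(F)c(F)c2)NC(=O)N1` is not yet measured. From compound 2 to compound 3 the change is methoxymethyl in place of trifluoromethyl on a double-bonded ring carbon, a methoxymethyl in place of a trifluoromethyl on a double-bonded ring carbon. Compound 1 also carries a methoxymethyl there and sits near compound 2, so no step beyond the scatter is expected, a 1.4-fold higher number from compound 2 to compound 3 (0.13 log units; within the scatter). Compound 3 is estimated at 270 nM, ranging from 130 nM to 560 nM.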

Compound 3, inhibition constant: 35 nM
The estimate for compound 3 lay 7.7-fold (0.89 log units) above the measured number; the whole stated range lies above it.
By their numbers in this assay, from the lowest: compound 3; then compounds 2 and 1 (each within the scatter of the next).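

In this assay, the double-bonded ring carbon proves sensitive to its substituent: methoxymethyl in place of trifluoromethyl gives a 5.7-fold lower number from compound 2 to compound 3 (0.76 log units; beyond the scatter) with the rest of the structure unchanged. With methoxymethyl held constant, the aromatic carbon also matters, as fluoro in place of hydrogen gives an 8.1-fold lower number from compound 1 to compound 3 (0.91 log units; beyond the scatter) in this series. No available evidence bears on the reason for either step.
The compounds shown leave open whether ethoxymethyl or a plain methyl on that ring carbon would keep the lower number. They also leave open whether the fluoro step would hold with trifluoromethyl there.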